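A dichlorophenyl swap in a weak antiproliferative series

A few compounds are considered here, and "the series" means these few. Any claim that something is new, unique, unknown or untested is made for them only; others in the source may bear on it.

Compounds measured so far in a functional assay on MDA-MB-436 cells (Homo sapiens) for antiproliferative activity, read by MTT assay, with a stated time of 24 h; a lower number here means a stronger inhibitor, a higher number a weaker inhibitor

Compound 1 `O=C(O)CC(NC(=O)c1ccc(Cl)cc1Cl)c1ccccc1` gives 78200 nM
Compound 2 `CC(C)(C)c1ccc(C(CC(=O)O)NC(=O)c2ccc(F)cc2)cc1` gives > 100000 nM (a limit)
Compound 3 `COc1ccc(C(=O)NC(CC(=O)O)c2ccc(C(C)(C)C)cc2)cc1` gives > 100000 nM (a limit)

Compound 3 gives > 100000 nM as a limit of the assay and not a number. Compound 2 likewise gives > 100000 nM as a limit. Compound 3 thus stands at the limit of > 100000 nM in this assay, at which 2 of the 3 values shown sit, with no number of its own.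

Compound 4 `CC(C)(C)c1ccc(C(CC(=O)O)NC(=O)c2ccc(Cl)cc2Cl)cc1` follows from compound 3 by one change, 2,4-dichlorophenyl in place of 4-methoxyphenyl on a carbonyl carbon. Of measured steps there is only a step that the two limits leave unreadable from compound 2 to compound 3 and it offers no size to carry over. The nearest guide is compound 1, which carries the same 2,4-dichlorophenyl and gives 78200 nM as a true number. Among the compounds with values here, no measured step covers what else separates compound 1 from compound 4, so confidence is low. A modest move toward stronger inhibition in this assay is expected, and a reading at the limit remains possible. The expected size is an at least 1.8-fold lower number from compound 3 to compound 4 (0.25 log units; that floor lies within the scatter) as an estimate set against a limit. For compound 4 the estimate is 55000 nM with a range from 20000 nM to 100000 nM as the expected bounds.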

Compound 4, half-maximal inhibitory concentration: > 100000 nM
Compound 4 ended at the assay's limit; the forecaster's own chance of this, stated with the estimate: 35%; at least 1.8-fold (0.25 log units) between middle value and limit.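

In this assay, 2,4-dichlorophenyl on a carbonyl carbon does not bring the tert-butyl series to a number, and compound 4 joins compound 2 and compound 3 at a reading that is a limit of the assay: the limit of > 100000 nM in this assay, at which 3 of the 4 values shown sit.
The steps among these three compounds cannot be read, so no order can be given for 2,4-dichlorophenyl, 4-methoxyphenyl and 4-fluorophenyl at this place.
Within the data shown here, the only step with any size is an at least 1.2-fold higher number from compound 1 to compound 4 (0.10 log units; that floor lies within the scatter), and with its floor inside the scatter it does not establish that tert-butyl in place of hydrogen on an aromatic carbon weakens the compound.
Among these compounds, compound 1 at 78200 nM remains the only true number in the set.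

The compounds shown leave open what 2,4-dichlorophenyl itself contributes on the core of compound 1, where no partner here differs from it on the carbonyl carbon alone.
Also open, from the compounds shown here alone, is whether an amine or a longer chain in place of the tert-butyl would give a number rather than a limit.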